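Working notes: from compound 1 to compound 4

This account rests on a few compounds, and the source may have more. Where it says the series, first, only, none or still open, it means among the compounds named here.

In a functional assay on MCF7 cells (Homo sapiens) for antiproliferative activity, read by MTT assay, with a stated time of 24 h (on this read-out higher numbers stand for weaker inhibition and lower numbers for stronger inhibition), compound 1 `CCCCc1oc2ccccc2c1C(=O)c1ccc(OCC(=O)N2CCCCC2)cc1` reads > 50000 nM as a limit and not a number, which places it at the limit of > 50000 nM in this assay, at which 1 of the 3 values shown sits, on the scale shown. Compound 2 `CCCCc1oc2ccccc2c1C(=O)c1ccc(OCC(=O)N2CCN(C(=O)OC(C)(C)C)CC2)cc1` gives 42200 nM and compound 3 `CCCCc1oc2ccccc2c1C(=O)c1ccc(OCC(=O)Nc2cccc(OC)c2)cc1` gives 38500 nM as measured numbers. Compound 4 `CCCCNC(=O)CCCOc1ccc(C(=O)c2c(CCCC)oc3ccccc23)cc1` carries 2-(butylcarbamoyl)ethyl in place of (piperidin-1-yl)carbonyl on a saturated chain carbon bound to an oxygen on an aromatic ring, counted as 2-(butylcarbamoyl)ethyl in place of (piperidin-1-yl)carbonyl on a saturated chain carbon bound to an oxygen on an aromatic ring for this change. For the measured compounds named here, the one measured step bearing on it, an at least 1.2-fold lower number from compound 1 to compound 3 (0.11 log units; that floor lies within the scatter) with (3-methoxyphenyl)amino in place of piperidin-1-yl, stays within the scatter. No step beyond the scatter is therefore expected, and the expected size is an at least 1.2-fold lower number from compound 1 to compound 4 (0.09 log units; that floor lies within the scatter) toward a slightly lower number. Compound 4 is estimated at 40000 nM with a range of 18000 nM to 80000 nM expected.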

Compound 4, half-maximal inhibitory concentration: > 50000 nM
Compound 4: a limit, no number; the forecaster's own chance of this, stated with the estimate: 40%; middle value at least 1.2-fold (0.09 log units) from the limit.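

In this assay compound 4 gives > 50000 nM, a limit and not a number, so the step from compound 1, itself a limit, cannot be read. For the compounds shown here, the top of the scale now holds a second compound: the limit of > 50000 nM in this assay, at which 2 of the 4 values shown sit. The one readable step is an at least 1.2-fold higher number from compound 3 to compound 4 (0.11 log units; that floor lies within the scatter), so the open chain with its hydrogen-bond donor at this place brings no gain the data can show.

As far as these compounds go, whether a free piperazine amine or a carboxylic acid at the end of the chain would give a step beyond the scatter stays open.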